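Working notes: trifluoromethoxy in place of fluoro, compound 4

A few compounds are considered here, and "the series" means these few. Any claim that something is new, unique, unknown or untested is made for them only; others in the source may bear on it.

In an ADME assay on WI-38 cells (Homo sapiens) for cytotoxicity, read by MTT assay, with a stated time of 72 h (on this read-out higher numbers stand for weaker inhibition and lower numbers for stronger inhibition), compound 1 (`O=C(CCc1cccc2c1B(O)OC2)Nc1cccc(Br)c1`) reads 20000 nM and compound 2 (`O=C(CCc1cccc2c1B(O)OC2)Nc1cccc(I)c1`) reads 71000 nM while compound 3 (`O=C(CCc1cccc2c1B(O)OC2)Nc1cccc(-c2ccc(F)cc2)c1`) stands lowest of the three at 4100 nM on these numbers. Compound 4 (`O=C(CCc1cccc2c1B(O)OC2)Nc1cccc(-c2ccc(OC(F)(F)F)cc2)c1`) has trifluoromethoxy in place of fluoro on an aromatic carbon, para to a large group (trifluoromethoxy in place of fluoro on an aromatic carbon). The nearest evidence is the exchange of bromo or iodo for 4-fluorophenyl, modest in one case (a 4.9-fold lower number from compound 1 to compound 3 (0.69 log units; beyond the scatter)) and large in the other (a 17-fold lower number from compound 2 to compound 3 (1.24 log units; beyond the scatter)). Iodo in place of bromo gave a modest step (a 3.6-fold higher number from compound 1 to compound 2 (0.55 log units; beyond the scatter)). Among the compounds with values here, no measured step changes a group on the 4-fluorophenyl itself, so these steps only loosely guide the size expected here. A small move to a lower number, within the scatter, is expected (a 1.4-fold lower number from compound 3 to compound 4 (0.14 log units; within the scatter)). Compound 4 is expected at 3000 nM within 1000 nM to 10000 nM in repeat measurements.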

Compound 4, half-maximal inhibitory concentration: 25000 nM
The estimate for compound 4 lay 8.3-fold (0.92 log units) below the measured number; measured number outside the range, above it.
By their numbers in this assay, from the lowest: compound 3; then compounds 1 and 4 (each within the scatter of the next); then compound 2.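

In this assay the substituent on the outer aromatic ring proves able to move the number: trifluoromethoxy in place of fluoro, para to a large group, gives a 6.1-fold higher number from compound 3 to compound 4 (0.79 log units; beyond the scatter). Keeping that ring therefore does not by itself hold the number at the level of compound 3; the group it carries also counts. No measurement at hand accounts for this step.

From the compounds shown here alone, how a methoxy, an amine or a carboxylic acid at this place would read remains open. So does whether a plain unsubstituted phenyl would sit nearer compound 3 or compound 4.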